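From methoxycarbonyl to hydroxymethyl on compound 1

The source may report more compounds than this note shows. Statements on the series, on what has been measured and on what is new or still open speak of the compounds shown alone.

Of the compounds shown here, two have been measured so far in a physicochemical assay for lipophilicity, at pH 7.4; a higher number here means a more lipophilic compound, a lower number a more polar compound. Compound 1 (`CCc1ccc(N(CC(C)C)S(=O)(=O)c2ccc3cc(OCC4CCOCC4)c(C(=O)OC)cc3c2)cc1`) gives 6.09, the higher of the two numbers, while compound 2 (`CCc1ccc(N(CC(C)C)S(=O)(=O)c2ccc3c(c2)C(=O)CC(C2CCOCC2)O3)cc1`) gives 4.21, a gap beyond the usual scatter. Compound 3 (`CCc1ccc(N(CC(C)C)S(=O)(=O)c2ccc3cc(OCC4CCOCC4)c(CO)cc3c2)cc1`) keeps the core of compound 1 but carries hydroxymethyl in place of methoxycarbonyl on an aromatic carbon, ortho to a (oxan-4-yl)methoxy group: hydroxymethyl in place of methoxycarbonyl on an aromatic carbon. Going by the values given here, no measured pair differs in one place only, so there is no direct precedent, and the expectation rests on this structural change alone. A downward step in this assay, beyond the scatter, is expected. The estimated step is a number 0.79 log units lower from compound 1 to compound 3 (beyond the scatter). For compound 3 the expected value is 5.3, with an estimated range from 4.8 to 5.8.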

Compound 3, distribution coefficient: 5.1
Estimate against measurement, compound 3: 0.20 log units above, within the range that was stated.
By their numbers in this assay, from the lowest: compound 2; then compound 3; then compound 1.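

In this assay, the series now has its first comparison of compounds that differ in one place: hydroxymethyl in place of methoxycarbonyl on this aromatic carbon, ortho to a (oxan-4-yl)methoxy group, gives a number 0.99 log units lower from compound 1 to compound 3 (beyond the scatter). The exchange removes a group of 4 heavy atoms with 0 hydrogen-bond donors and brings in one of 2 heavy atoms with 1 hydrogen-bond donor, so size and donor count change together and this single step cannot separate them. Nothing measured here accounts for the size of the step.

As far as these compounds go, how a carboxylic acid, an amine or a longer chain such as hydroxyethyl would stand at this position in this assay remains open. From the compounds shown here alone, it is also open whether the step would keep its size with another group in place of the (oxan-4-yl)methoxy group.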